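Carbamate to urea on the shared core

The source may hold more compounds than are shown below. What is called first, only, known or untested is meant among the compounds shown, and "the series" means these compounds.

Compound 3 `O=C(Nc1ccc(-c2ccccc2)cn1)Oc1ccccc1` is the carbamate of the set; in an assay on isolated protein (Aquatica lateralis) for inhibition of Luciferin 4-monooxygenase (Luciola lateralis), read by a luciferase reporter, tested at 10 uM (a lower number here means less inhibition, a higher number more inhibition at the concentration tested (going by the name of the read-out)), compound 3 gives 0%. Compound 1 `O=C(Nc1ccccn1)c1ccccc1` gives 27% and compound 2 `c1ccc(CNc2ccc(-c3ccccc3)cn2)cc1` gives 20%, so compound 3 stands lowest of the three numbers, its gap to each of the other two beyond the usual scatter. Compound 4 `O=C(Nc1ccccc1)Nc1ccc(-c2ccccc2)cn1` differs from compound 3 in one place: anilino in place of phenoxy on a carbonyl carbon. Within the data shown here, no step between measured compounds covers this change, so its size is not known from the series. A small step upward in this assay is expected, likely one that stays within the scatter. For compound 4 the estimate in this assay is 8%, with a range from 0% to 25%. The step thus expected, a number 8 percentage points higher from compound 3 to compound 4 (within the scatter), is modest.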

Compound 4, a percentage reported as inhibition, at one concentration (the size of the read-out at that concentration, not a potency): 20%
The estimate for compound 4 lay 12 percentage points below the measured number; low and high end bracket the measured number.
By their numbers in this assay, from the lowest: compound 3; then compounds 2, 4 and 1 (each within the scatter of the next).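

In this assay the change to anilino in place of phenoxy on a carbonyl carbon gives the first step read at this position, a number 20 percentage points higher from compound 3 to compound 4 (beyond the scatter), so the group at this place does bear on the number. The change swaps only the oxygen for a nitrogen, and a hydrogen-bond acceptor gives way to a hydrogen-bond donor. Nothing at hand bears on why the number moves. Still open, from the compounds shown here alone, is whether a benzylamino or a methylamino group on the same carbonyl carbon would keep the higher number.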